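Benzyl on the ring nitrogen: what compound 3 might tolerate

A few compounds are considered here, and "the series" means these few. Any claim that something is new, unique, unknown or untested is made for them only; others in the source may bear on it.

Compound 1 `O=C(NCCO)c1c[nH]c2ccccc2c1=O` has been examined in an ADME assay on CCRF-CEM cells (Homo sapiens) for cytotoxicity; a higher number here means that more compound is tolerated, a lower number that less compound is tolerated. In this assay compound 1 gives > 100 uM, which is a limit of the assay and not a number. Compound 2 `O=C(NCCO)c1c[nH]c2ccc(Cl)cc2c1=O` carries chloro in place of hydrogen on an aromatic carbon. In this assay compound 2 gives > 100 uM, again a limit rather than a number. Between the two lies a step that the two limits leave unreadable from compound 1 to compound 2, and all the pair shows is the limit of > 100 uM in this assay, at which 2 of the 2 values shown sit.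

Compound 3 `O=C(NCCO)c1cn(Cc2ccccc2)c2ccccc2c1=O` has not yet been measured. It differs from compound 1 by benzyl in place of hydrogen on an aromatic nitrogen. Going by the values given here, no measured step touches this nitrogen, and the single step that is known, from compound 1 to compound 2, cannot be read, so nothing among the measured compounds sets the size or direction of the change in this assay. Compound 3 is therefore only estimated: in this assay it is expected to give 70 uM, within 15 uM to 150 uM. That corresponds to an expected step of an at least 1.4-fold lower number from compound 1 to compound 3 (0.15 log units; that floor lies within the scatter), an estimate rather than an observation.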

Compound 3, half-maximal toxic concentration: > 100 uM
Compound 3: no number, only a limit (the forecaster's own chance of this, stated with the estimate: 40%); middle value at least 1.4-fold (0.15 log units) from the limit.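

Compound 3 also gives only a limit and not a number in this assay, so neither its step from compound 1 nor any other step among compound 1, compound 2 and compound 3 can be read: the limit of > 100 uM in this assay, at which 3 of the 3 values shown sit. The compounds shown leave open how much of each is tolerated in this assay, and whether chloro or benzyl changes that at all.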